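Trading 2-methoxyphenyl for 4-ethylphenyl on the carbonyl

The source may hold more compounds than are shown below. What is called first, only, known or untested is meant among the compounds shown, and "the series" means these compounds.

Compound 1 `COc1cc2ncnc(Nc3ccc(NC(=O)c4ccc(C)cc4)cc3)c2cc1OC` gives 19000 nM
Compound 2 `COc1cc2ncnc(Nc3ccc(NC(=O)c4ccccc4OC)cc3)c2cc1OC` gives > 100000 nM (a limit)

In a functional assay on MCF7 cells (Homo sapiens) for inhibition, read by MTT assay (on this read-out lower numbers stand for stronger inhibition and higher numbers for weaker inhibition), compound 2 has no exact number, only a limit (the limit of > 100000 nM in this assay, at which 1 of the 2 values shown sits). Compound 3 `CCc1ccc(C(=O)Nc2ccc(Nc3ncnc4cc(OC)c(OC)cc34)cc2)cc1` differs from compound 2 with 4-ethylphenyl in place of 2-methoxyphenyl on a carbonyl carbon. Within the data shown here, one measured step bears on this change (an at least 5.2-fold higher number from compound 1 to compound 2 (0.72 log units; beyond the scatter)), and it brought in the same 2-methoxyphenyl group that compound 3 gives up. Losing that group is therefore expected to reverse the step, with a lower number of similar size to that shift, landing near compound 1 at 19000 nM on the scale. In this assay the expected change is clear of the scatter (an at least 5.0-fold lower number from compound 2 to compound 3 (0.69 log units; beyond the scatter)). For compound 3 the estimated value is 20000 nM with an expected range from 7000 nM to 60000 nM in this read-out.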

Compound 3, half-maximal inhibitory concentration: 65000 nM
Estimate against measurement, compound 3: 3.3-fold (0.51 log units) below; measured number outside the range, above it.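

In this assay, the 4-ethylphenyl group on the carbonyl carbon does not behave like the 4-methylphenyl group: adding a single methyl there gives a 3.4-fold higher number from compound 1 to compound 3 (0.53 log units; beyond the scatter), so even this small change at this place shifts the number beyond the scatter, towards weaker inhibition. On these data alone, exchanging 2-methoxyphenyl for 4-ethylphenyl gives an at least 1.5-fold lower number from compound 2 to compound 3 (0.18 log units; that floor lies within the scatter), and since that figure is only a floor, the true size of this change stays unknown. Compound 2 has a limit rather than an exact number: the limit of > 100000 nM in this assay, at which 1 of the 3 values shown sits.

As far as these compounds go, with only these compounds, it remains open whether the number would keep rising with a longer chain such as propyl in place of the ethyl. It is also unclear how a group of a different kind, such as an amine or a carboxylic acid, would fare at this place.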